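A few compounds are considered here, and "the series" means these few. Any claim that something is new, unique, unknown or untested is made for them only; others in the source may bear on it.

Compound 1 `COc1c(N2CCN(CC#N)C(C)C2)c(F)cc2c(=O)c(C(=O)O)cn(C3CC3)c12` gives 354 ug/mL in an ADME assay on Vero cells (Chlorocebus sabaeus) for cytotoxicity, read by MTT assay, with a stated time of 72 h (a higher number here means that more compound is tolerated, a lower number that less compound is tolerated), and compound 2 `COc1c(N2CCN(CCC#N)C(C)C2)c(F)cc2c(=O)c(C(=O)O)cn(C3CC3)c12` gives 500 ug/mL in this assay, the two sitting within the scatter of each other, as the step of a 1.4-fold higher number from compound 1 to compound 2 (0.15 log units; within the scatter) shows. Compound 3 `COC(=O)CCN1CCN(c2c(F)cc3c(=O)c(C(=O)O)cn(C4CC4)c3c2OC)CC1C` gives only a limit of this assay, > 1000 ug/mL. Compound 4 `COc1c(N2CCN(CCC(C)=O)C(C)C2)c(F)cc2c(=O)c(C(=O)O)cn(C3CC3)c12` differs from compound 1 by 2-oxopropyl in place of cyano on a saturated chain carbon bound to an amine nitrogen in a ring. Two measured steps start from compound 1 at the same place on the chain: the step of a 1.4-fold higher number from compound 1 to compound 2 (0.15 log units; within the scatter) stays within the scatter, whereas the step of an at least 2.8-fold higher number from compound 1 to compound 3 (0.45 log units; beyond the scatter) goes beyond it. A modest rise in tolerated concentration is therefore expected, roughly a 1.6-fold higher number from compound 1 to compound 4 (0.19 log units; within the scatter). Compound 4 is thus estimated to give about 550 ug/mL, with a likely range from 280 ug/mL to 1000 ug/mL.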

Compound 4, half-maximal cytotoxic concentration: 9.84 ug/mL
The estimate for compound 4 lay 56-fold (1.75 log units) above the measured number; measured number below the stated range.
By their numbers in this assay, from the lowest: compound 4; then compounds 1 and 2 (each within the scatter of the next). At a limit, above all of these: compound 3.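

In this assay, the group on this saturated chain carbon can shift the tolerated concentration far more than compounds 1 and 2 suggested, with a 36-fold lower number from compound 1 to compound 4 (1.56 log units; beyond the scatter) and a 51-fold lower number from compound 2 to compound 4 (1.71 log units; beyond the scatter) as the measure. Methyl in place of methoxy on a carbonyl carbon, a change at the end of the chain, gives an at least 100-fold lower number from compound 3 to compound 4 (2.00 log units; beyond the scatter) so having a carbonyl there does not by itself set the number. Compound 3 gives a limit, so that last step is only a floor: the limit of > 1000 ug/mL in this assay, at which 1 of the 4 values shown sits.

The compounds shown leave open whether this drop is particular to the acetyl group or would also come with an amine, a carboxylic acid or a longer chain at this place. They also do not show why the number falls.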